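The source may report more compounds than this note shows. Statements on the series, on what has been measured and on what is new or still open speak of the compounds shown alone.

Measured compounds:
- compound 1, `N#CC1=C(N)N(c2ccc(S(N)(=O)=O)cc2)C2=C(C(=O)CCC2)C1/C=C/c1ccccc1`: 2%
- compound 2, `COc1ccc(C2C(C#N)=C(N)N(c3ccc(S(N)(=O)=O)cc3)C3=C2C(=O)CCC3)cc1`: 30%
- compound 3, `N#CC1=C(N)N(c2ccc(S(N)(=O)=O)cc2)C2=C(C(=O)CCC2)C1c1ccc([N+](=O)[O-])cc1`: 85%

All three numbers come from a functional assay on Ehrlich cells (Mus musculus) for antiproliferative activity, read by trypan blue exclusion, with a stated time of 2 h, tested at 10 ug/mL; on this read-out higher numbers stand for a stronger effect at the one concentration tested and lower numbers for a weaker effect. Compound 3 stands highest of the three, and both of its steps to the others are beyond the scatter: a number 55 percentage points higher from compound 2 to compound 3 (beyond the scatter), and a number 83 percentage points higher from compound 1 to compound 3 (beyond the scatter). The smaller of the two swaps, methoxy against nitro on the aromatic carbon, already moves the read-out a long way; exchanging the whole 2-phenylethenyl group for 4-nitrophenyl moves it further still.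

The next compound, compound 4 (`N#CC1=C(N)N(c2ccc(S(N)(=O)=O)cc2)C2=C(C(=O)CCC2)C1c1ccc(Cl)cc1Cl`), has not been measured in this assay. Compared with compound 3 the change is 2,4-dichlorophenyl in place of 4-nitrophenyl on a saturated ring carbon. Going by the values given here, two measured steps bear on it: the one from the methoxy compound to the nitro compound, which is the only change made on that aromatic ring, and the one from the phenylethenyl compound to the nitro compound. Both were large and both ended on compound 3, the top number, so leaving the 4-nitrophenyl is more likely to cost than to gain. Among the compounds with values here, no dichlorophenyl compound has been measured, so the size is uncertain. Compound 4 is expected to give 45%, within 15% to 80%. The expected step is thus a number 40 percentage points lower from compound 3 to compound 4 (beyond the scatter), a fall beyond the scatter.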

Compound 4, a percentage reported as activity, at one concentration (the size of the read-out at that concentration, not a potency): 40%
Beside the measured number, compound 4's estimate is 5 percentage points above it, within the range that was stated.
By their numbers in this assay, from the lowest: compound 1; then compounds 2 and 4 (each within the scatter of the next); then compound 3.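

In this assay, the step of a number 45 percentage points lower from compound 3 to compound 4 (beyond the scatter) shows that the high reading of the 4-nitrophenyl compound does not carry over to every substituted phenyl group on this saturated ring carbon, since the 2,4-dichlorophenyl group loses most of it. The step of a number 10 percentage points higher from compound 2 to compound 4 (within the scatter) leaves 2,4-dichlorophenyl and 4-methoxyphenyl indistinguishable here, so among the three phenyl groups only 4-nitrophenyl stands apart, while the step of a number 38 percentage points higher from compound 1 to compound 4 (beyond the scatter) adds a third phenyl-bearing compound that stands clear of the 2-phenylethenyl compound. Nothing in the data shown accounts for these differences.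

The compounds shown leave open whether the gain of compound 3 belongs to the nitro group itself or would also appear with another group on the ring, such as a single chlorine in 4-chlorophenyl, a nitrile in 4-cyanophenyl or no substituent at all in plain phenyl. They also leave open how a nitro group elsewhere on the ring, as in 3-nitrophenyl, or a saturated group such as cyclohexyl would read at this carbon.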